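Sulfur methylation step toward compound 3

The source may hold more compounds than are shown below. What is called first, only, known or untested is meant among the compounds shown, and "the series" means these compounds.

The series is followed in a functional assay on EL4 cells (Mus musculus) for inhibition, tested at 100 uM; a lower number here means less inhibition, a higher number more inhibition at the concentration tested (going by the name of the read-out). Compound 1 `CSc1nccc2c1ncn2C1O[C@H](CO)[C@@H](O)[C@H]1O` carries a methylsulfanyl group on the shared core. In this assay compound 1 gives < 5%, which is a limit of the assay and not a number. Compound 2 `OC[C@H]1O[C@@H](n2cnc3c(S)nccc32)C[C@@H]1O` carries a sulfanyl group instead and differs from compound 1 elsewhere as well. In this assay compound 2 gives < 5%, again a limit rather than a number. Compound 2 therefore stands at the floor of the numbers shown, as the limit of < 5% in this assay, at which 2 of the 2 values shown sit, records; no order between the two measured compounds can be read. Compound 3 `CSc1nccc2c1ncn2[C@H]1C[C@H](O)[C@@H](CO)O1` is the next step from compound 2: methyl in place of hydrogen on a sulfur. Among the measured compounds shown here, no measured pair is separated by this change alone, so the size of the step is open; the expectation is for no change beyond the scatter, with a step that the limit leaves unreadable from compound 2 to compound 3 as the estimated step. Compound 3 is estimated at 3%, within 0% to 12%.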

Compound 3, a percentage reported as inhibition, at one concentration (the size of the read-out at that concentration, not a potency): < 5%
Compound 3 ended at the assay's limit (the forecaster's own chance of this, stated with the estimate: 80%); the middle value does not contradict the limit.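

In this assay compound 3 gives < 5% as a limit of the assay and not a number. Compound 2 also rests on a limit, so no step can be read between compound 2 and compound 3. Whether methyl in place of hydrogen on a sulfur changes inhibition at all stays open: the limit of < 5% in this assay, at which 3 of the 3 values shown sit.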